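Taking the nitro group off compound 1

The source may report more compounds than this note shows. Statements on the series, on what has been measured and on what is new or still open speak of the compounds shown alone.

In a functional assay on LNCaP cells (Homo sapiens) for cytotoxicity, read by MTT assay, with a stated time of 5 days (on this read-out higher numbers stand for weaker inhibition of growth and lower numbers for stronger inhibition of growth), compound 1 `Cc1ccc(NS(=O)(=O)c2ccccc2)c([N+](=O)[O-])c1` gives 2.95 nM and holds the lower of the two numbers available. Among the measured compounds shown here, compound 2 `Cc1ccc(S(=O)(=O)Nc2ccc(C)cc2[N+](=O)[O-])cc1` gives 39800 nM as the only other number. For compound 3 `Cc1ccc(/C=N/c2ccc(C)cc2)cc1` the entry is "not determined" (no result reported) and it adds nothing to the comparison.

Compound 4 `Cc1ccc(NS(=O)(=O)c2ccccc2)cc1` has not been measured. Its change from compound 1 is hydrogen in place of nitro on an aromatic carbon in counted terms, that is, hydrogen in place of nitro on an aromatic carbon, ortho to a large group and meta to a methyl group.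

For the measured compounds named here, one measured step bears on this, and only indirectly. The step of a 13000-fold higher number from compound 1 to compound 2 (4.13 log units; beyond the scatter) is large and beyond the scatter, and it comes from methyl in place of hydrogen on an aromatic carbon. Going by the values given here, that is a different change, and compound 2 keeps the nitro, so no measured pair isolates the nitro group. It does show that one small edit to compound 1 can carry the number very far. A large step to a higher number is therefore expected here, though with wide uncertainty.

Compound 4 is estimated at 2000 nM with an expected range from 20 nM to 40000 nM in this assay as a rough figure. This estimate means a 680-fold higher number from compound 1 to compound 4 (2.83 log units; beyond the scatter) as the expected step, well beyond the scatter.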

Compound 4, concentration for 50% growth inhibition: 21300 nM
Compound 4: the middle estimate sits 11-fold (1.03 log units) below what was measured; measured number inside the range.
By their numbers in this assay, from the lowest: compound 1; then compounds 4 and 2 (each within the scatter of the next).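

In this assay, among the compounds shown here, hydrogen in place of nitro on an aromatic carbon, ortho to a large group and meta to a methyl group, gives a 7200-fold higher number from compound 1 to compound 4 (3.86 log units; beyond the scatter), and this is the first pair that isolates the nitro group. The low number of compound 1 therefore depends on the nitro at this position, which the earlier comparison could not show because compound 2 keeps that group. Alongside a 13000-fold higher number from compound 1 to compound 2 (4.13 log units; beyond the scatter), the new step shows that two different single edits to compound 1, one removing the nitro and one adding a methyl on an aromatic carbon, each carry the number far upward, and nothing available on these compounds gives a reason for the size of either step.

Going by these compounds, only nitro and hydrogen can be compared at this position, so it remains open whether an amine, a nitrile or a carboxylic acid there would keep a number close to that of compound 1. On these data alone, it is also open whether the nitro carries similar weight on a core bearing the added methyl of compound 2.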